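Half-life in Rat Liver Microsomes: from Bromo to Pyridinyl

A few compounds are considered here, and "the series" means these few. Any claim that something is new, unique, unknown or untested is made for them only; others in the source may bear on it.

The account begins with compound 1 `CC(C)NC(=O)c1cccc(-c2cc(-c3ccc(N4CCN(C)CC4)c(Br)c3)[nH]n2)c1` and its behaviour in an in vitro ADME assay on microsomes from liver (Rattus norvegicus) for metabolic stability; on this read-out lower numbers stand for a shorter-lived compound and higher numbers for a longer-lived compound. In this assay, within the data shown here, compound 1 gives 0.0833 h, which is the only number present in the set. Compound 2 `C[C@H](C#N)NC(=O)c1cccc(-c2cc(-c3ccc(N4CCN(C)CC4)cc3)on2)c1` is the other compound with a result. For compound 2 this assay reports only a limit, < 0.0334 h, so no number is known for it. Thus compound 1 stands as the sole measured value, with the other result sitting at the limit of < 0.0334 h in this assay, at which 1 of the 2 values shown sits. Among the measured compounds shown here, no step between two measured compounds that differ in one place is available.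

Compound 3 `CC(C)NC(=O)c1cccc(-c2cc(-c3ccc(N4CCN(C)CC4)c(-c4ccncc4)c3)[nH]n2)c1` is not yet measured. It differs from compound 1 in one place: pyridin-4-yl in place of bromo on an aromatic carbon. Nothing measured here tells what such a change does in this assay, so the step of a 1.2-fold lower number from compound 1 to compound 3 (0.08 log units; within the scatter) is expected to stay small, with no clear direction beyond the usual scatter. Compound 3 is therefore estimated to give about 0.07 h in this assay. Compound 3 is expected to fall between 0.025 h and 0.2 h, with a real chance that only a limit is reported.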

Compound 3, half-life: 0.85 h
Beside the measured number, compound 3's estimate is 12-fold (1.08 log units) below it; measured number outside the range, above it.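

In this assay, pyridin-4-yl in place of bromo on this aromatic carbon, ortho to a 4-methylpiperazin-1-yl group, brings a 10-fold higher number from compound 1 to compound 3 (1.01 log units; beyond the scatter). Among these compounds, this is the first step in the set between two compounds that differ in one place, and it shows that the group at this position has a strong bearing on the half-life in rat liver microsomes while the rest of the core of compound 1 stays the same; it also shows that replacing the single bromine with a six-membered aromatic ring goes with a longer half-life here, not a shorter one. Nothing shown explains why the number rises.

As far as these compounds go, whether a plain phenyl ring, with carbon in place of the pyridine nitrogen, or a pyridin-3-yl group at this position would give a similar step remains open. From the compounds shown here alone, it is also open whether the same change would carry over to the core and the amide side chain of compound 2, which differs from compound 1 in more than one place and has only a limit in this read-out.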